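Replacing 3-Chlorophenyl with Cyclohexyl on the Carbonyl

The compounds below may be only part of what the source reports. "The series", "measured", "known", "first", "only" and "open" are said of these compounds alone.

In a toxicity assay on THP-1 cells (Homo sapiens) for inhibition (on this read-out higher numbers stand for lower toxicity in this test and lower numbers for higher toxicity in this test), compound 1 `Cc1cccc(C(=O)Nc2ncc(-c3ccccc3)n2C)c1` gives > 50000 nM, which is a limit of the assay. Compound 2 `Cn1c(-c2ccccc2)cnc1NC(=O)c1ccccc1` gives > 100000 nM, which is also a limit. Compound 3 `Cn1c(-c2ccccc2)cnc1NC(=O)c1cccc(Cl)c1` gives > 50000 nM, again a limit. None of the three has an exact number, so compound 3 cannot be ranked against the other two.

Compound 4 `Cn1c(-c2ccccc2)cnc1NC(=O)C1CCCCC1` keeps the shared core but has cyclohexyl in place of 3-chlorophenyl on a carbonyl carbon. The aromatic ring of carbon only thus gives way to a non-aromatic one.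

The closest evidence comes from three changes on the aromatic ring: a step that the two limits leave unreadable from compound 1 to compound 2, a step that the two limits leave unreadable from compound 1 to compound 3 and a step that the two limits leave unreadable from compound 2 to compound 3. Among the measured compounds shown here, none of these replaces the ring itself, and none has a readable size, so no measured step can be carried over to this change.

The expectation therefore rests on compound 3 and its limit of > 50000 nM. No step beyond the usual scatter is expected in this assay, in either direction. The expected step is a step that the limit leaves unreadable from compound 3 to compound 4. For compound 4, the estimated value is 60000 nM, with an expected range from 30000 nM to 100000 nM.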

Compound 4, half-maximal cytotoxic concentration: > 100000 nM
Compound 4 ended at the assay's limit; the forecaster's own chance of this, stated with the estimate: 85%; middle value at least 1.6-fold (0.22 log units) away from the limit.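

Compound 4 gives only a limit of the assay, as do compound 1, compound 2 and compound 3, and none of the steps from these three to compound 4 can be read. Going by these compounds, what stays open is whether the four compounds differ at all in this assay, and whether any group on the carbonyl carbon changes their toxicity.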